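A few compounds are considered here, and "the series" means these few. Any claim that something is new, unique, unknown or untested is made for them only; others in the source may bear on it.

Measured so far in a functional assay on MCF7 cells (Homo sapiens) for antiproliferative activity, read by MTT assay, with a stated time of 72 h; on this read-out lower numbers stand for stronger inhibition and higher numbers for weaker inhibition:
- compound 1, `COc1ccc(-c2cn(C/C=C3\OC(=O)C(OCc4ccccc4)=C3OCc3ccccc3)nn2)cc1`: compound 1 gives 39100 nM.
- compound 2, `O=C1O/C(=C\Cn2cc(-c3cc(F)cc(F)c3)nn2)C(OCc2ccccc2)=C1OCc1ccccc1`: compound 2 returns only > 100000 nM, a limit of the assay and not a number.
- compound 3, `O=C1O[C@H]([C@@H](O)Cn2cc(-c3cccc(O)c3)nn2)C(OCc2ccccc2)=C1OCc1ccccc1`: compound 3 gives 51800 nM.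

Compound 3 holds the highest of the two numbers shown; its nearest neighbour is compound 1, and the gap between the two lies within the scatter, so no order between them can be read. Compound 2 stands at the limit of > 100000 nM in this assay, at which 1 of the 3 values shown sits.

Compound 4, `Cc1ccc(-c2cn(C[C@H](O)[C@H]3OC(=O)C(OCc4ccccc4)=C3OCc3ccccc3)nn2)cc1`, is the next compound to be read in this assay. It keeps the core of compound 3 and changes only the aryl group: 4-methylphenyl in place of 3-hydroxyphenyl on an aromatic carbon.

Among the measured compounds shown here, the one measured step that touches the same aryl position is an at least 2.5-fold higher number from compound 1 to compound 2 (0.40 log units; beyond the scatter). That step sits on the alkene-linked core of compound 1, not on the hydroxy-bearing core of compound 3, and it exchanges different groups from the ones here, so it bears on the present change only loosely. Compound 1, with a methoxy-bearing aryl, and compound 3, with a hydroxy-bearing aryl, lie within the scatter of each other, which gives no sign that a small change of the aryl substituent moves the number far. The step of a 1.2-fold lower number from compound 3 to compound 4 (0.06 log units; within the scatter) is therefore expected to stay within the scatter. For compound 4 in this assay the estimate is 45000 nM, with a range from 18000 nM to 110000 nM.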

Compound 4, half-maximal inhibitory concentration: > 100000 nM
Compound 4: no number, only a limit; the forecaster's own chance of this, stated with the estimate: 20%; middle value at least 2.2-fold (0.34 log units) away from the limit.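

In this assay, compound 4 returns > 100000 nM, a limit of the assay and not a number. On the hydroxy-bearing core, 4-methylphenyl in place of 3-hydroxyphenyl gives an at least 1.9-fold higher number from compound 3 to compound 4 (0.28 log units; that floor lies within the scatter), so the shown floor does not separate the two compounds, and the true size of the step stays unknown. The alkene-linked core already had a step of this kind, an at least 2.5-fold higher number from compound 1 to compound 2 (0.40 log units; beyond the scatter), and the new result adds a matching case on the second core: on each core, the compound whose aryl group carries an oxygen substituent gives a number, while the one without it sits at the same limit, a pattern that rests on these two pairs only: the limit of > 100000 nM in this assay, at which 2 of the 4 values shown sit.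

The exchange from 3-hydroxyphenyl to 4-methylphenyl alters the substituent and its place on the phenyl ring together, so the compounds shown cannot tell which of the two matters, and the real value of compound 4 remains open. Also open, as far as these compounds go, is how this core would read with an amine or a carboxylic acid on the phenyl ring in place of the hydroxy or methyl group.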